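Benzothiazole-amide series: aryl to dimethylfuran swap at the carbonyl

The source may report more compounds than this note shows. Statements on the series, on what has been measured and on what is new or still open speak of the compounds shown alone.

Compound 1 `O=C(Nc1nc2ccc(-c3cccc(CO)c3)cc2s1)c1ccc(F)cc1Cl` gives 98200 nM in a functional assay on A549 cells (Homo sapiens) for inhibition, read by MTT assay, with a stated time of 24 h; on this read-out higher numbers stand for weaker inhibition and lower numbers for stronger inhibition. Compound 2 `O=C(Nc1nc2ccc(-c3cccc(CO)c3)cc2s1)c1ccccc1Br` gives 97500 nM. Going by the values given here, compound 2 holds the lower of the two numbers so far, but the step of a 1.0-fold lower number from compound 1 to compound 2 (0.00 log units; within the scatter) is within the scatter, so the two cannot be told apart; both sit at weak inhibition. Among the compounds with values here, the only measured step exchanges one six-membered aromatic ring of carbon only for another on the carbonyl carbon and moves nothing.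

Compound 3 `Cc1cc(C)c(C(=O)Nc2nc3ccc(-c4cccc(CO)c4)cc3s2)o1` differs from compound 2 by 3,5-dimethylfuran-2-yl in place of 2-bromophenyl on a carbonyl carbon, bringing in a five-membered aromatic ring with one hetero atom and one hydrogen-bond acceptor. Within the data shown here, no measured step covers a ring of this kind, so the single step that bears on the place says only that variation there has left the number unchanged. The expectation for compound 3 is therefore a step of a 1.1-fold lower number from compound 2 to compound 3 (0.03 log units; within the scatter), with a wide range. Compound 3 is estimated at 90000 nM, between 30000 nM and 300000 nM.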

Compound 3, half-maximal inhibitory concentration: 95000 nM
Beside the measured number, compound 3's estimate is 1.1-fold (0.02 log units) below it; low and high end bracket the measured number.
By their numbers in this assay, from the lowest: compounds 3, 2 and 1 (each within the scatter of the next).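

In this assay the swap of 2-bromophenyl for 3,5-dimethylfuran-2-yl on a carbonyl carbon gives a 1.0-fold lower number from compound 2 to compound 3 (0.01 log units; within the scatter) and the swap of 2-chloro-4-fluorophenyl for the same furan gives a 1.0-fold lower number from compound 1 to compound 3 (0.01 log units; within the scatter) with the read-out still at weak inhibition. The flat result at this position, on a carbonyl carbon whose other neighbour is an amide-type nitrogen, now extends beyond six-membered aromatic rings of carbon only to a five-membered aromatic ring with a hetero atom and a hydrogen-bond acceptor. No independent data bear on this result.

On these data alone, whether a saturated amine, a carboxylic acid or a longer alkyl chain at this carbonyl carbon would separate from these three numbers remains open. Also open, as far as these compounds go, is whether changes to the shared core, rather than to the group on the carbonyl, would shift the number.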